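From 3,4-dihydroxyphenyl to 1H-pyrrol-2-yl on the shared core

The compounds below may be only part of what the source reports. "The series", "measured", "known", "first", "only" and "open" are said of these compounds alone.

In a functional assay on K562 cells (Homo sapiens) for inhibition, read by MTT assay, with a stated time of 72 h (a lower number here means a stronger inhibitor, a higher number a weaker inhibitor), compound 1 `CCOC(=O)C1=C(Nc2ccccc2)S/C(=C\c2ccc(O)c(O)c2)C1=O` gives 5200 nM, the lowest of the three numbers in the series. Compound 2 `CCOC(=O)C1=C(Nc2ccccc2)S/C(=C\c2ccc([N+](=O)[O-])c(O)c2)C1=O` gives 12700 nM, and compound 3 `CCOC(=O)C1=C(Nc2ccccc2)S/C(=C\c2cc(OC)c(O)c(OC)c2)C1=O` gives 31700 nM.

Compound 4 `CCOC(=O)C1=C(Nc2ccccc2)S/C(=C\c2ccc[nH]2)C1=O` keeps the core of compound 1 but carries 1H-pyrrol-2-yl in place of 3,4-dihydroxyphenyl on a double-bonded chain carbon bound to a double-bonded ring carbon.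

For the measured compounds named here, the only measured single-place change is modest: a 2.4-fold higher number from compound 1 to compound 2 (0.39 log units; beyond the scatter). It exchanges nitro for hydroxy on an aromatic carbon, so it bears on compound 4 only partly. Going by the values given here, no measured compound carries 1H-pyrrol-2-yl. Still, both measured compounds lacking 3,4-dihydroxyphenyl lie above compound 1, with compound 2 at 12700 nM and compound 3 at 31700 nM. A move toward a weaker number in this assay is therefore expected, of similar size to those gaps, and the estimated step is a 2.9-fold higher number from compound 1 to compound 4 (0.46 log units; beyond the scatter). The estimate for compound 4 is 15000 nM, with an expected range of 5000 nM to 45000 nM.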

Compound 4, half-maximal inhibitory concentration: 71000 nM
Compound 4: middle estimate off by 4.7-fold (0.68 log units), on the low side, and the stated range ends below it.
By their numbers in this assay, from the lowest: compound 1; then compound 2; then compound 3; then compound 4.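

In this assay, exchanging the whole aromatic group on a double-bonded chain carbon bound to a double-bonded ring carbon gives a 14-fold higher number from compound 1 to compound 4 (1.14 log units; beyond the scatter), which is large beside the modest 2.4-fold higher number from compound 1 to compound 2 (0.39 log units; beyond the scatter), where the 3,4-dihydroxyphenyl is altered only at one hydroxy. Within these compounds, the number therefore depends strongly on which aromatic group stands at this place, and 1H-pyrrol-2-yl, a five-membered aromatic ring with 1 hetero atom, gives the highest number of the series. No evidence at hand accounts for the size of this step.

Compound 4 changes ring size, ring atoms and both hydroxy groups in one step, and the compounds shown cannot separate these changes. A plain phenyl or a furan-2-yl group at this place would begin to tell them apart.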